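The compounds below may be only part of what the source reports. "The series", "measured", "known", "first", "only" and "open" are said of these compounds alone.

The study concerns cytotoxicity measured in a functional assay on C6 cells (Rattus norvegicus) for cytotoxicity, read by MTT assay, with a stated time of 24 h; on this read-out lower numbers stand for stronger inhibition and higher numbers for weaker inhibition. Compound 1 `Cc1ccc(-c2cs/c(=N/NC(=O)CSc3nnnn3-c3ccccc3)n2-c2ccccc2)cc1` gives 14.7 ug/mL in this assay. Compound 2 `COc1ccc(-c2cs/c(=N/NC(=O)CSc3ncccn3)n2-c2ccccc2)cc1` gives 102 ug/mL in this assay, the highest of the two numbers, and its gap to compound 1 lies beyond the usual scatter. Among the compounds with values here, no pair of measured compounds differs in only one place, so no single step has been measured.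

Compound 3 `Cc1ccc(-c2cs/c(=N/NC(=O)CSc3ncccn3)n2-c2ccccc2)cc1` has not yet been measured in this assay. It differs from compound 2 in one place, (methyl in place of methoxy on an aromatic carbon), the site being an aromatic carbon of a six-membered aromatic ring of carbon only, para to a large group. Compound 1 also carries the methyl, but it differs from compound 3 in a second place too, so it cannot show this change alone.

In this assay a modest step toward a lower number is expected, a 1.6-fold lower number from compound 2 to compound 3 (0.20 log units; within the scatter), only slightly beyond the scatter. Compound 3 is therefore estimated at 65 ug/mL, with a range from 30 ug/mL to 140 ug/mL.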

Compound 3, half-maximal inhibitory concentration: 85 ug/mL
Estimate against measurement, compound 3: 1.3-fold (0.12 log units) below; low and high end bracket the measured number.
By their numbers in this assay, from the lowest: compound 1; then compounds 3 and 2 (each within the scatter of the next).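

In this assay the change from 4-methoxyphenyl to 4-methylphenyl, taken alone, gives a 1.2-fold lower number from compound 2 to compound 3 (0.08 log units; within the scatter) and so shows no readable difference at this aromatic carbon, para to a large group, when pyrimidin-2-yl sits on the sulfur. Within the data shown here, the change on the sulfur, with the methyl held constant, gives a 5.8-fold higher number from compound 1 to compound 3 (0.76 log units; beyond the scatter) and is the only one of the two steps beyond the scatter, so here the number responds to the group on the sulfur and not to the swap of methoxy for methyl. Nothing measured here offers an explanation for either step.

Going by these compounds, it remains open whether a hydroxyl group or a chlorine atom on that aromatic carbon would read like methyl and methoxy. On these data alone, it is also open how an amine or a carboxylic acid on the sulfur-linked group would read.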